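This account rests on a few compounds, and the source may have more. Where it says the series, first, only, none or still open, it means among the compounds named here.

Compound 1 `CC(C)n1cc(-c2ccnc3[nH]c(C4CCNCC4)cc23)ccc1=O` is the reference point of this comparison. In an ADME assay on cells (Hepatocyte, Rattus norvegicus) for metabolic stability (on this read-out higher numbers stand for fast clearance and lower numbers for slow clearance), compound 1 gives < 1 uL/min, which is a limit of the assay rather than a number (the limit of < 1 uL/min in this assay, at which 1 of the 3 values shown sits). The two other measured compounds bracket the scale: compound 2 `COc1cc(F)ccc1-c1ccnc2[nH]c(C3CCOCC3)cc12` gives 97 uL/min in this assay, while compound 3 `CN(C)C(=O)CN1CCC(c2cc3c(-c4ccc(=O)n(CCC5CCOCC5)c4)ccnc3[nH]2)CC1` gives 14 uL/min in this assay. The compound still to be measured, compound 4 `CNC(=O)CN1CCC(c2cc3c(-c4ccc(=O)n(C(C)C)c4)ccnc3[nH]2)CC1`, differs from compound 1 by (methylcarbamoyl)methyl in place of hydrogen on an amine nitrogen in a ring. Within the data shown here, no measured pair isolates this change, so the expectation rests on the spread among compounds 1, 2 and 3. In this assay a modest step upward, an at least 3.0-fold higher number from compound 1 to compound 4 (0.47 log units; beyond the scatter), is expected. Compound 4 is therefore estimated at 3 uL/min in this assay, most likely between 1 uL/min and 10 uL/min.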

Compound 4, intrinsic clearance in a liver preparation (reported as CLH), per the amount of preparation that the assay uses: 8.9 uL/min
Beside the measured number, compound 4's estimate is 3.0-fold (0.47 log units) below it; the range from low to high includes it.
By their numbers in this assay, from the lowest: compounds 4 and 3 (each within the scatter of the next); then compound 2. At a limit, below all of these: compound 1.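

In this assay, (methylcarbamoyl)methyl in place of hydrogen on the amine nitrogen in the ring gives an at least 8.9-fold higher number from compound 1 to compound 4 (0.94 log units; beyond the scatter), the first step shown at this position. With this group, compound 4 gives a measured number, 8.9 uL/min. The value of compound 1 is a limit and not a number, so the full size of the step stays unknown: the limit of < 1 uL/min in this assay, at which 1 of the 4 values shown sits.

On these data alone, whether a simple methyl, a longer chain or a carboxylic acid on this nitrogen would give a smaller or larger step stays open. So does how much of the step belongs to the amide rather than to the carbon chain that carries it.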